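The compounds below may be only part of what the source reports. "The series", "measured", "known", "first", "only" and "open" are said of these compounds alone.

Measured compounds:

compound 1, `O=Cc1ccc(-c2cn3ccnc3c(-c3ccc4ncn(C5CCCCC5)c4c3)n2)cc1`, 23.7%
compound 2, `O=Cc1ccc(-c2cn3ccnc3c(-c3ccc4ncn(Cc5ccccc5)c4c3)n2)cc1`, 23.7%
compound 3, `c1cn2cc(-c3ccc4c(c3)ncn4C3CCCCC3)nc(-c3ccc4ncn(C5CCCCC5)c4c3)c2n1`, 3.05%

In a functional assay on OVCAR-3 cells (Homo sapiens) for inhibition, read by sulforhodamine B assay, with a stated time of 48 h, tested at 10 uM (a lower number here means less inhibition, a higher number more inhibition at the concentration tested (going by the name of the read-out)), compound 1 gives 23.7% and compound 2 gives 23.7%; the change between them is benzyl in place of cyclohexyl on an aromatic nitrogen, and the step is no change at the digits printed from compound 1 to compound 2 (within the scatter). Compound 3 gives 3.05%, the lowest of the three, with a gap to compound 1 and compound 2 that lies beyond the scatter. The difference between the core of compound 3 and the core of compound 1 is not broken down here.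

Compound 4, `c1ccc(Cn2cnc3ccc(-c4nc(-c5ccc6c(c5)ncn6C5CCCCC5)cn5ccnc45)cc32)cc1`, is not yet measured. It differs from compound 3 by benzyl in place of cyclohexyl on an aromatic nitrogen, the same change that was made from compound 1 to compound 2. Because that earlier step was no change at the digits printed from compound 1 to compound 2 (within the scatter), the step from compound 3 to compound 4 is expected to be of similar size, namely a number 2 percentage points higher from compound 3 to compound 4 (within the scatter). For compound 4 in this assay the estimate is 5%, expected between -6% and 16%.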

Compound 4, a percentage reported as inhibition, at one concentration (the size of the read-out at that concentration, not a potency): -35.7%
The estimate for compound 4 lay 40.7 percentage points above the measured number; the measured number lies below the stated range.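

In this assay the change of benzyl in place of cyclohexyl on an aromatic nitrogen gives a number 38.8 percentage points lower from compound 3 to compound 4 (beyond the scatter) and does not repeat the step seen on the core of compound 1. The same change therefore cannot be carried from one core to the other in this series: the same change on two cores in this assay, no change at the digits printed (within the scatter) from compound 1 to compound 2 and a number 38.8 percentage points lower (beyond the scatter) from compound 3 to compound 4, 38.8 percentage points apart, beyond the scatter of two such steps. These two pairs show that the step depends on the core, but not which part of the core is responsible, nor how the change would read on any further core.

Going by these compounds, it remains open whether a longer alkyl chain, or a chain ending in an amine or a carboxylic acid, on that aromatic nitrogen would differ between the two cores. Also open, on these data alone, is whether the large step is specific to benzyl.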